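Carbamate chain variation in a small antiproliferative series

The source may hold more compounds than are shown below. What is called first, only, known or untested is meant among the compounds shown, and "the series" means these compounds.

compound 1 `COC(=O)N1N=C(c2ccccc2)NN=C1c1ccccc1` in a functional assay on A549 cells (Homo sapiens) for antiproliferative activity, read by sulforhodamine B assay; on this read-out lower numbers stand for stronger inhibition and higher numbers for weaker inhibition: 39500 nM; 39500 nM (2 entries)
compound 2 `CCCOC(=O)N1N=C(c2ccccc2)NN=C1c1ccccc1` in this assay: > 100000 nM (a limit of the assay)
compound 3 `CC(C)CCOC(=O)N1N=C(c2ccccc2)NN=C1c1ccccc1` in this assay: 44200 nM; 44200 nM (2 entries)

Compound 1 and compound 3 sit within the usual scatter of each other, so no order is claimed between them. Compound 2 stands apart only as a limit of the assay, with no single number, and two further entries also give no number; see (the limit of > 100000 nM in this assay, at which 1 of the 3 values shown sits).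

Compound 4 `O=C(OCCCl)N1N=C(c2ccccc2)NN=C1c1ccccc1` is not yet measured. Its difference from compound 2 is chloro in place of methyl on a saturated chain carbon, two bonds along the chain from an oxygen next to a carbonyl group. Going by the values given here, no measured step covers this change, so the expectation rests on the series as a whole. A small move toward stronger inhibition, not clearly beyond the scatter, is expected: the expected step is an at least 1.6-fold lower number from compound 2 to compound 4 (0.22 log units; that floor lies within the scatter). Compound 4 is therefore estimated at 60000 nM, within 20000 nM to 200000 nM, with a real chance that only a limit is again reported.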

Compound 4, half-maximal inhibitory concentration: 101000 nM
Compound 4: the middle estimate sits 1.7-fold (0.23 log units) below what was measured; the range from low to high includes it.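

The step from compound 2 to compound 4 cannot be read, because compound 2 stands only at a limit: the limit of > 100000 nM in this assay, at which 1 of the 4 values shown sits. The compounds shown leave open what chloro in place of methyl does when both partners give a single number.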